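Adding bromo to compound 2: an expected inhibition

The source may report more compounds than this note shows. Statements on the series, on what has been measured and on what is new or still open speak of the compounds shown alone.

Compound 1 `O=S(=O)(c1ccccc1)c1ccc(O)nn1` is the plainest member of this small series; in a functional assay on the whole organism for inhibition, with Rattus norvegicus as the target, at a dose of 10 mg/kg (a lower number here means a weaker effect, a higher number a stronger effect of the compound at the dose given), compound 1 gives 40%. Compound 2 `O=S(=O)(c1ccc(O)nn1)c1ccccc1F` carries a fluoro in place of hydrogen on an aromatic carbon, and in this assay compound 2 gives 79%, a change of a number 39 percentage points higher from compound 1 to compound 2 (beyond the scatter). Within the data shown here, compound 2 therefore stands highest of the two numbers measured so far, with compound 1 the nearest and well beyond the scatter below it.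

Compound 3 `O=S(=O)(c1ccc(O)nn1)c1ccc(Br)cc1F` differs from compound 2 by bromo in place of hydrogen on an aromatic carbon. Among the measured compounds shown here, no measured step involves a bromo, so the only step on record, that from compound 1 to compound 2, speaks to a different change and only loosely to this one. Since compound 2 already gives 79%, and the read-out is bounded, compound 3 is expected to show at most a modest step, a number 1 percentage points higher from compound 2 to compound 3 (within the scatter), within the scatter. Compound 3 is estimated at 80%, between 60% and 95%.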

Compound 3, a percentage reported as inhibition, in the whole organism at one dose (the size of the read-out at that dose, not a potency): 81%
Beside the measured number, compound 3's estimate is 1 percentage points below it; the range from low to high includes it.
By their numbers in this assay, from the lowest: compound 1; then compounds 2 and 3 (each within the scatter of the next).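

In this assay, bromo in place of hydrogen on an aromatic carbon gives a number 2 percentage points higher from compound 2 to compound 3 (within the scatter) and so leaves the read-out indistinguishable from that of compound 2. The position para to a large group and meta to a fluoro group therefore accepts a bromine atom at this dose without a change that can be told from the scatter, a finding the earlier fluoro step could not give. Nothing on hand explains this result.

From the compounds shown here alone, whether a smaller or more elaborate group at this place, such as a methoxy group, an amine or a carboxylic acid, would also leave the read-out unchanged remains open. Also open, going by these compounds, is whether bromo would give the same result without the fluoro group, and whether compound 2 and compound 3 would stay together at other doses.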